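Swapping Vinyl for Bromo at an Assay Limit

A few compounds are considered here, and "the series" means these few. Any claim that something is new, unique, unknown or untested is made for them only; others in the source may bear on it.

Compound 1 `C=Cc1nc2ccccc2s1`: > 40000 nM (a limit)
Compound 2 `C=Cc1nc2ccccc2o1`: > 40000 nM (a limit)
Compound 3 `C=Cc1sc(-c2ccc(F)cc2)nc1C(=O)OCC`: > 40000 nM (a limit)

These three compounds were tested in a functional assay on HCT-116 cells (Homo sapiens) for cytotoxicity, with a stated time of 3 days; on this read-out higher numbers stand for weaker inhibition and lower numbers for stronger inhibition. None of the three results is an exact number. Compound 2 cannot be ranked against compound 1 or compound 3, as the data show only (the limit of > 40000 nM in this assay, at which 3 of the 3 values shown sit).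

Compound 4 `Brc1nc2ccccc2o1` keeps the core of compound 2 but carries bromo in place of vinyl on an aromatic carbon, next to the ring nitrogen and next to the ring oxygen: bromo in place of vinyl on an aromatic carbon. Within the data shown here, all three measured compounds carry vinyl, and no measured pair shows what such a swap does. The best expectation in this assay is therefore no step beyond the scatter, although a real gain in inhibition cannot be excluded. This expectation rests on compound 2, whose result of > 40000 nM is a limit. The estimated change is a number no higher from compound 2 to compound 4 (the limit leaves the size open), and it is expected to be small. The expected value for compound 4 is 40000 nM, within an estimated range from 15000 nM to 80000 nM.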

Compound 4, half-maximal inhibitory concentration: > 40000 nM
Compound 4: no number, only a limit (the forecaster's own chance of this, stated with the estimate: 70%); the middle value lies on the limit itself.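

No step can be read between compound 2 and compound 4, since each result is a limit and not a number: the limit of > 40000 nM in this assay, at which 4 of the 4 values shown sit.

The compounds shown leave open how strongly any of the four inhibits in this assay and whether bromo in place of vinyl changes that at all.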